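The compounds below may be only part of what the source reports. "The series", "measured", "known", "first", "only" and "open" are said of these compounds alone.

Measured so far:
Compound 1, `Nc1ccccc1NC(=O)c1ccc(CSC(=S)N2CCN(c3ccc(F)cc3)CC2)cc1`: 64.5%
Compound 2, `CC1CCN(C(=S)SCc2ccc(C(=O)Nc3ccccc3N)cc2)CC1`: 72.5%

In a functional assay on HeLa cells (Homo sapiens) for antiproliferative activity, read by CCK-8 assay, with a stated time of 72 h, tested at 8 uM (a lower number here means a weaker effect, a higher number a stronger effect of the compound at the concentration tested), compound 1 gives 64.5%, and compound 2 gives 72.5%. On these two numbers compound 1 sits at the low end, but compound 2 lies within the usual scatter of it, so the two cannot be separated and no order between them can be claimed. Within the data shown here, no step between two measured compounds that differ in a single place is available, so nothing is known from the data about how a change at the amine nitrogen in the ring affects this assay.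

Compound 3, `Nc1ccccc1NC(=O)c1ccc(CSC(=S)N2CCN(c3ccncc3)CC2)cc1`, has not been measured. It differs from compound 1 in one place: pyridin-4-yl in place of 4-fluorophenyl on an amine nitrogen in a ring. Among the measured compounds shown here, with no comparable step to lean on, only a modest expectation can be formed. The author expects the step of a number 6.5 percentage points lower from compound 1 to compound 3 (within the scatter) to be small, most likely a slight drop or none beyond the scatter. Compound 3 is therefore estimated at 58%, with a range from 40% to 75%.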

Compound 3, a percentage reported as inhibition, at one concentration (the size of the read-out at that concentration, not a potency): 77.4%
Beside the measured number, compound 3's estimate is 19.4 percentage points below it; the measured number lies above the stated range.
By their numbers in this assay, from the lowest: compounds 1, 2 and 3 (each within the scatter of the next, the first and the last beyond it).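

In this assay the amine nitrogen in the ring now has its first readable step: pyridin-4-yl in place of 4-fluorophenyl gives a number 12.9 percentage points higher from compound 1 to compound 3 (beyond the scatter). This shows that the read-out at this position responds to swapping one six-membered aromatic ring for another, even though the rest of the molecule stays the same and the step is modest. The change replaces a carbon-only ring bearing fluorine with a ring holding one hetero atom and one hydrogen-bond acceptor, but no available measurement bears on why the number rises.

Among these compounds, the single pair leaves open whether the rise goes with the ring nitrogen or with the loss of the fluorine, a question that a plain phenyl at the same place would help to separate, and whether pyridin-3-yl or pyrimidin-2-yl would give a similar step. It also leaves open whether the step would hold as a difference in potency, since the read-out is the size of the effect at one concentration only.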